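Working notes: from compound 3 to compound 4

The source may hold more compounds than are shown below. What is called first, only, known or untested is meant among the compounds shown, and "the series" means these compounds.

Measured so far:
compound 1 `CC(=O)c1cc2ccc(OCCCn3cc(CNC(=O)CCCCC4CCSS4)nn3)cc2oc1=O` — 40.7%
compound 2 `O=C(CCCCC1CCSS1)NCc1cn(CCCOc2ccc3cc(C(=O)O)c(=O)oc3c2)nn1` — 73.5%
compound 3 `O=C(CCCCC1CCSS1)NCc1cn(CCCOc2ccc3cc(-c4ccccc4)c(=O)oc3c2)nn1` — 23.1%

All three numbers come from a functional assay on PC-12 cells (Rattus norvegicus) for cytotoxicity, read by MTT assay, with stated times of 3 h and 2 h, tested at 50 uM; a lower number here means a weaker effect, a higher number a stronger effect of the compound at the concentration tested. Compound 3 stands lowest of the three, with both other compounds beyond the scatter above it: the steps are a number 17.6 percentage points lower from compound 1 to compound 3 (beyond the scatter) and a number 50.4 percentage points lower from compound 2 to compound 3 (beyond the scatter). Between the two higher compounds the step is a number 32.8 percentage points higher from compound 1 to compound 2 (beyond the scatter), so the group on the shared core moves the read-out strongly.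

Compound 4 `COc1ccc(-c2cc3ccc(OCCCn4cc(CNC(=O)CCCCC5CCSS5)nn4)cc3oc2=O)cc1` is the next compound to be measured. Relative to compound 3 the change is methoxy in place of hydrogen on an aromatic carbon, placed on the six-membered aromatic ring of carbon only, para to a large group. None of the three measured steps bears directly on this change: each of them swaps the group attached to the shared core itself, whereas here the phenyl of compound 3 is kept and only a methoxy is added to it. Going by the values given here, there is therefore no measured step from which a direction can be read. The expectation is a step of no size beyond the scatter, a number 1.9 percentage points higher from compound 3 to compound 4 (within the scatter), so that compound 4 stays near compound 3. Compound 4 is estimated at 25% in this assay, with a range from 10% to 45%.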

Compound 4, a percentage reported as activity, at one concentration (the size of the read-out at that concentration, not a potency): 65.7%
Compound 4: middle estimate off by 40.7 percentage points, on the low side, and the stated range ends below it.
By their numbers in this assay, from the lowest: compound 3; then compound 1; then compounds 4 and 2 (each within the scatter of the next).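

In this assay, going by these compounds alone, the earlier steps only swapped the group on the shared core, whereas phenyl to 4-methoxyphenyl keeps that group and still gives a number 42.6 percentage points higher from compound 3 to compound 4 (beyond the scatter), so a small addition on an aromatic carbon of the six-membered ring, para to a large group, produces a large step. An aryl group on the shared core therefore does not by itself go with a low read-out: the picture from compound 3 alone fails given a number 25 percentage points higher from compound 1 to compound 4 (beyond the scatter), and a number 7.8 percentage points lower from compound 2 to compound 4 (within the scatter) leaves compound 4 and the carboxy compound 2 indistinguishable. No supporting data are available to explain the step from the added methoxy.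

Still open, going by these compounds, is whether this step is specific to methoxy or would also appear with a hydroxy, a fluorine, a dimethylamino group or a longer ether chain on the same carbon of the phenyl ring. Because all these read-outs come from one concentration, the compounds also leave open how the 4-methoxyphenyl and carboxy compounds would compare across a range of concentrations.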